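The source may report more compounds than this note shows. Statements on the series, on what has been measured and on what is new or still open speak of the compounds shown alone.

Of the compounds shown here, two in a shared core have been measured in a functional assay on CCRF-CEM cells (Homo sapiens) for inhibition, read by sulforhodamine B assay, with a stated time of 48 h, tested at 10 uM; on this read-out lower numbers stand for less inhibition and higher numbers for more inhibition at the one concentration tested (going by the name of the read-out). Compound 1 `CC(=O)c1ccc(-c2cn3ccnc3c(-c3ccc4ncn(C5CCCCC5)c4c3)n2)cc1` carries an acetyl group and gives 1.1% in this assay. Compound 2 `Clc1ccc(-c2cn3ccnc3c(-c3ccc4ncn(C5CCCCC5)c4c3)n2)cc1` carries a chloro group in the same position and gives 11.4% in this assay. Among the measured compounds shown here, the one step between them, a number 10.3 percentage points higher from compound 1 to compound 2 (beyond the scatter), is the only measured change so far, and on these two numbers compound 2 stands highest, with compound 1 as its only neighbour, lower by that same modest step.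

Compound 3 `Fc1ccccc1-c1cn2ccnc2c(-c2ccc3ncn(C4CCCCC4)c3c2)n1` has not yet been measured. It differs from compound 2 by 2-fluorophenyl in place of 4-chlorophenyl on an aromatic carbon. The measured step from compound 1 to compound 2 changed the group on the outer aromatic ring, so it bears on this change only loosely: it shows that such a swap moved this assay by a modest amount, and both numbers sit low. The step from compound 2 to compound 3 is therefore expected to be small, a number 4.4 percentage points lower from compound 2 to compound 3 (within the scatter), pointing slightly downward or staying within the scatter. Compound 3 is estimated to give 7% in this assay, within a range from -5% to 20%.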

Compound 3, a percentage reported as inhibition, at one concentration (the size of the read-out at that concentration, not a potency): 22.5%
Beside the measured number, compound 3's estimate is 15.5 percentage points below it, and the stated range ends below it.
By their numbers in this assay, from the lowest: compound 1; then compound 2; then compound 3.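

In this assay the swap of 4-chlorophenyl for 2-fluorophenyl gives a number 11.1 percentage points higher from compound 2 to compound 3 (beyond the scatter) and the swap of 4-acetylphenyl for 2-fluorophenyl gives a number 21.4 percentage points higher from compound 1 to compound 3 (beyond the scatter) in the same direction. This position now shows three distinct levels rather than two, so with the rest of the shared core unchanged, the group on this aromatic carbon can move the reading by more than the scatter, and the smaller 4-chlorophenyl step is not the limit of what a change here can do. No supporting data explain the rise, so no cause can be assigned to it.

The swap from compound 2 to compound 3 changes both the halogen and its place on the outer ring, so the compounds shown cannot tell which of the two matters; 2-chlorophenyl and 4-fluorophenyl would separate them. Also open, from the compounds shown here alone, is how an outer ring carrying an amine or a carboxylic acid would read, and whether any group here reaches strong inhibition at the one concentration tested.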